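Chlorophenyl sulfonamides against mitochondrial malate dehydrogenase

A few compounds are considered here, and "the series" means these few. Any claim that something is new, unique, unknown or untested is made for them only; others in the source may bear on it.

Working notes on the series. Compound 1 `O=S(=O)(Nc1ccc2oc(-c3ccccc3)nc2c1)c1ccccc1Cl` carries a 2-chlorophenyl on the sulfonyl sulfur. In an assay on isolated protein for inhibition of malate dehydrogenase, mitochondrial (Sus scrofa), with stated times of 45 min and 30 min (a higher number here means a weaker inhibitor, a lower number a stronger inhibitor), compound 1 gives > 63000 nM, which is a limit of the assay rather than a number. Compound 2 `O=S(=O)(Nc1ccc(-c2nc3ccccc3o2)cc1)c1ccc(Cl)s1` joins the sulfonamide to the shared core at another point. In this assay compound 2 gives > 63000 nM, again a limit and not a number. Both values thus rest on the same line, (the limit of > 63000 nM in this assay, at which 2 of the 2 values shown sit), so no ranking between the two is possible from what has been measured. Compound 3 `O=S(=O)(Nc1ccc2oc(-c3ccccc3)nc2c1)c1cccc(Cl)c1` is not yet measured and differs from compound 1 by 3-chlorophenyl in place of 2-chlorophenyl on a sulfonyl sulfur. For the measured compounds named here, no step between measured compounds is available, so the size of this change has no direct guide. Because compound 1 sits at the limit > 63000 nM in this assay, the step that the limit leaves unreadable from compound 1 to compound 3 is expected to be none beyond the scatter, and a limit is again the likely report. Compound 3 is therefore expected to give 80000 nM in this assay, with a range of 25000 nM to 250000 nM.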

Compound 3, half-maximal inhibitory concentration: > 63000 nM
Compound 3: a limit, no number; the forecaster's own chance of this, stated with the estimate: 80%; the middle value is on the limit's open side.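

Compound 1 and compound 3 both stand as limits and not numbers in this assay, so no step between them can be read: the limit of > 63000 nM in this assay, at which 3 of the 3 values shown sit.

The compounds shown leave open whether any member of the series gives a measurable value in this assay, and with it how 3-chlorophenyl and 2-chlorophenyl on a sulfonyl sulfur compare.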